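A few compounds are considered here, and "the series" means these few. Any claim that something is new, unique, unknown or untested is made for them only; others in the source may bear on it.

Compound 1 `CCC(=O)NC[C@@H]1C[C@H]1c1cccc2c1OC(C(C)C)N2` is the starting point. In an assay on NIH3T3 cells with melatonin receptor type 1B (Homo sapiens) as the target (on this read-out lower numbers stand for stronger inhibition and higher numbers for weaker inhibition), compound 1 gives 0.32 nM. Compound 2 `CC(C)C(=O)NC[C@@H]1C[C@H]1c1cccc2c1OC(C(C)C)N2` differs from it by methyl in place of hydrogen on a saturated chain carbon bound to a carbonyl carbon and a saturated chain carbon. In this assay compound 2 gives 2.5 nM, so the change brought a 7.8-fold higher number from compound 1 to compound 2 (0.89 log units; beyond the scatter). Compound 3 `CC(=O)NC[C@@H]1C[C@H]1c1cccc2nc(CCCCc3ccccc3)oc12` is built on a different core; the difference between the two cores is not broken down here. In this assay compound 3 gives 0.37 nM, a value that lies within the usual scatter of the value of compound 1.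

Compound 4 `CCC(=O)NC[C@@H]1C[C@H]1c1cccc2nc(CCCCc3ccccc3)oc12` has not yet been measured. It differs from compound 3 by methyl in place of hydrogen on a saturated chain carbon bound to a carbonyl carbon. This is the same kind of change as the one between the first two compounds, but not the same change: there the saturated chain carbon was bound to a carbonyl carbon and a saturated chain carbon, so that the change read ethyl to isopropyl, whereas here it is bound to a carbonyl carbon and the change reads methyl to ethyl. The expected step is a 1.1-fold higher number from compound 3 to compound 4 (0.03 log units; within the scatter), smaller than the measured step because a 7.8-fold higher number from compound 1 to compound 2 (0.89 log units; beyond the scatter) arose from a change at a differently surrounded place, and the surroundings here are not the same. For compound 4 the estimate is 0.4 nM, with an expected range from 0.15 nM to 1.2 nM.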

Compound 4, inhibition constant: 0.07 nM
Compound 4: middle estimate off by 5.7-fold (0.76 log units), on the high side, outside the stated range (below it).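

In this assay the methyl placed on the saturated chain carbon bound to a carbonyl carbon gave a 5.3-fold lower number from compound 3 to compound 4 (0.72 log units; beyond the scatter) and so lowered the number, whereas the earlier change of the same kind gave a 7.8-fold higher number from compound 1 to compound 2 (0.89 log units; beyond the scatter) and raised it. The two steps run in opposite directions and lie further apart than repeated measurements would explain, so in this series the effect of adding this methyl on one core cannot simply be carried over to the other: the same change on two cores in this assay, a 7.8-fold higher number (0.89 log units; beyond the scatter) from compound 1 to compound 2 and a 5.3-fold lower number (0.72 log units; beyond the scatter) from compound 3 to compound 4, 41-fold (1.62 log units) apart, beyond the scatter of two such steps. Among the compounds shown here, this does not show what separates the two results: the steps differ in their core and also in their starting chain, methyl to ethyl in one case and ethyl to isopropyl in the other, and each core contributes only one step.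

The compounds shown leave open whether the change from ethyl to isopropyl would also raise the number on the core of compound 3, and whether the change from methyl to ethyl would lower it on the core of compound 1. They also leave open how a longer chain such as propyl, or a ring such as cyclopropyl, would read in place of the ethyl on either core.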